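Removing a Phenolic Hydroxy: Two Cores, One Kind of Change

This account rests on a few compounds, and the source may have more. Where it says the series, first, only, none or still open, it means among the compounds named here.

Of the compounds shown here, three have been tested in a functional assay on HepG2 cells (Homo sapiens) for antiproliferative activity, read by MTT assay, with a stated time of 48 h; a lower number here means a stronger inhibitor of growth, a higher number a weaker inhibitor of growth. Compound 1 `COC(=O)N1N=C(c2ccccc2)CC1c1cc(OC)c(OC)c(OC)c1` gives 3950 nM. Compound 2 `COC(=O)N1N=C(c2cccc(O)c2)CC1c1cc(OC)c(OC)c(OC)c1` gives 650 nM, the lowest number of the three. Compound 3 `COC(=O)N1N=C(c2ccccc2)CC1c1ccc(OC)c(O)c1` gives 9810 nM, the highest number of the three, and the difference between the cores of compound 3 and compound 2 is not broken down here.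

Compound 1 and compound 2 differ in one place, (hydrogen in place of hydroxy on an aromatic carbon), and that step, a 6.1-fold higher number from compound 2 to compound 1 (0.78 log units; beyond the scatter), lies beyond the scatter of this assay. Compound 4 `COC(=O)N1N=C(c2ccccc2)CC1c1ccc(OC)cc1` has not yet been measured; it differs from compound 3 in one place, (hydrogen in place of hydroxy on an aromatic carbon). The place is not the same word for word: in compound 3 the hydroxy that leaves sits ortho to a methoxy group (2 heavy atoms) and meta to a large group, whereas in compound 2 it sits only meta to a large group. The change from compound 3 to compound 4 is therefore the same kind of change as that from compound 2 to compound 1, not the same change.

Resting on that one earlier step, the number for compound 4 is expected to rise, a 2.5-fold higher number from compound 3 to compound 4 (0.41 log units; beyond the scatter). The surroundings of the hydroxy differ between compound 3 and compound 2, and the step is expected to be smaller than the earlier one. The starting point is compound 3, which gives 9810 nM. In this assay compound 4 is estimated at 25000 nM, within a range of 8000 nM to 80000 nM.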

Compound 4, concentration for 50% growth inhibition: 12000 nM
Compound 4: middle estimate off by 2.1-fold (0.32 log units), on the high side; the range from low to high includes it.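

In this assay, replacing a hydroxy with hydrogen on an aromatic carbon did not carry the same result from one core to the other: the same change on two cores in this assay, a 6.1-fold higher number (0.78 log units; beyond the scatter) from compound 2 to compound 1 and a 1.2-fold higher number (0.09 log units; within the scatter) from compound 3 to compound 4, 5.0-fold (0.70 log units) apart, beyond the scatter of two such steps

The new step, a 1.2-fold higher number from compound 3 to compound 4 (0.09 log units; within the scatter), means that compound 3 and compound 4 cannot be told apart in this assay, so the clear step seen on the core of compound 1 cannot be assumed to hold on the core of compound 3. What this does not show is why the two steps part, since the pairs differ in their cores and also in where the hydroxy sits, ortho to a methoxy group in compound 3 but only meta to a large group in compound 2, and two pairs cannot separate these differences or support a rule for the series.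

Going by these compounds, whether an amine or a carboxylic acid in place of the hydroxy would follow the step on the core of compound 1 or the one on the core of compound 3 remains open. Also open, on these data alone, is how the same exchange would behave on either core with the methoxy group replaced by a longer chain such as an ethoxy group.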